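The source may report more compounds than this note shows. Statements on the series, on what has been measured and on what is new or still open speak of the compounds shown alone.

Measured so far:
Compound 1 `COc1cc(Nc2nc(C(=N)Nc3ccccc3)cc3c(-c4ccccc4)n[nH]c23)cc(OC)c1OC`: 3900 nM
Compound 2 `N=C(Nc1ccccc1)c1cc2c(-c3ccccc3)n[nH]c2c(NC2CCCCC2)n1`: 850 nM

In a functional assay on HT-1080 cells (Homo sapiens) for cytotoxicity, read by MTT assay, with a stated time of 72 h (a lower number here means a stronger inhibitor, a higher number a weaker inhibitor), compound 1 gives 3900 nM, the highest of the two numbers shown. Among the measured compounds shown here, compound 2, which carries cyclohexyl in place of 3,4,5-trimethoxyphenyl on a nitrogen of the shared core, gives 850 nM in this assay, and the step of a 4.6-fold lower number from compound 1 to compound 2 (0.66 log units; beyond the scatter) is the only measured step available.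

Compound 3 `COc1cc(Nc2nc(C(=N)Nc3cccc(C(F)(F)F)c3)cc3c(-c4ccccc4)n[nH]c23)cc(OC)c1OC` differs from compound 1 in one place: trifluoromethyl in place of hydrogen on an aromatic carbon. This change sits on the anilino phenyl, not on the nitrogen where compound 1 and compound 2 differ, so the measured step says nothing about it directly. For the measured compounds named here, no measured step bears on the anilino phenyl at all, and the 3,4,5-trimethoxyphenyl group is kept, which in compound 1 went with the weaker of the two numbers.

Going by the values given here, with no comparable step to lean on, compound 3 is expected to stay close to compound 1, the step of a 1.3-fold lower number from compound 1 to compound 3 (0.11 log units; within the scatter) being small and within the scatter in either direction. The estimate for compound 3 in this assay is 3000 nM, with a range from 1000 nM to 9000 nM.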

Compound 3, half-maximal inhibitory concentration: 6700 nM
The estimate for compound 3 lay 2.2-fold (0.35 log units) below the measured number; measured number inside the range.
By their numbers in this assay, from the lowest: compound 2; then compounds 1 and 3 (each within the scatter of the next).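

In this assay, among the compounds shown here, trifluoromethyl in place of hydrogen on the phenyl ring of the anilino group gives a 1.7-fold higher number from compound 1 to compound 3 (0.24 log units; within the scatter), the first measured step at this ring. For the compounds shown here, the earlier pair showed only that changing the group on the other nitrogen can move the number beyond the scatter, with a 4.6-fold lower number from compound 1 to compound 2 (0.66 log units; beyond the scatter), whereas this addition of 4 heavy atoms, with the 3,4,5-trimethoxyphenyl group kept, leaves compound 3 and compound 1 within the scatter of each other. Nothing available gives a reason for this result.

What stands open is whether this ring tolerates other groups equally, since a single substituent at a single place cannot show how an amine, a carboxylic acid or a longer chain such as butyl would read here, or whether trifluoromethyl at another place on the ring would give a similar number. From the compounds shown here alone, it also remains open whether the same change would stay within the scatter on the cyclohexyl compound 2, the lowest number so far, because the step from compound 1 to compound 3 was read only with the 3,4,5-trimethoxyphenyl group in place.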